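A few compounds are considered here, and "the series" means these few. Any claim that something is new, unique, unknown or untested is made for them only; others in the source may bear on it.

Measured in a functional assay on PC-3 cells (Homo sapiens) for cytotoxicity, read by MTT assay, with a stated time of 72 h; a higher number here means a weaker inhibitor, a lower number a stronger inhibitor:
- compound 1 `CNC(=O)c1cc(Oc2ccc(C(=O)/C=C/c3cccc(Br)c3)cc2)ccn1`: 3400 nM
- compound 2 `CNC(=O)c1cc(Oc2ccc(C(=O)/C=C/c3ccc(Cl)c(Cl)c3)cc2)ccn1`: 8260 nM
- compound 3 `CNC(=O)c1cc(Oc2ccc(C(=O)/C=C/c3ccc(OC)c(OC)c3OC)cc2)ccn1`: "not determined" (no result reported)

Of the two numbers available, compound 2 has the higher, 8260 nM, which makes it the weaker inhibitor of the pair. Compound 4 `CNC(=O)c1cc(Oc2ccc(C(=O)/C=C/c3ccc(F)cc3Cl)cc2)ccn1` changes the aryl group on the chain: 2-chloro-4-fluorophenyl in place of 3,4-dichlorophenyl on a double-bonded chain carbon bound to a double-bonded chain carbon. For the measured compounds named here, no measured step shows this exact swap. The closest evidence is a change at the same place, a 2.4-fold higher number from compound 1 to compound 2 (0.39 log units; beyond the scatter), which is modest. A step of similar modest size is therefore expected, probably towards a lower number because compound 1 gives 3400 nM. The expected move is a 1.5-fold lower number from compound 2 to compound 4 (0.18 log units; within the scatter). In this assay the estimate for compound 4 is 5500 nM, with an expected range of 2200 nM to 14000 nM.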

Compound 4, half-maximal inhibitory concentration: 4760 nM
The estimate for compound 4 lay 1.2-fold (0.06 log units) above the measured number, and the stated range covers the measured number.
By their numbers in this assay, from the lowest: compounds 1, 4 and 2 (each within the scatter of the next, the first and the last beyond it).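

In this assay, 2-chloro-4-fluorophenyl gives a 1.7-fold lower number from compound 2 to compound 4 (0.24 log units; within the scatter) and a 1.4-fold higher number from compound 1 to compound 4 (0.15 log units; within the scatter). Compound 4 thus lies within the scatter of both earlier compounds, although those two differ by more than the scatter, so it does not separate from either. Nothing available explains these small steps. Every measured group at this place is a phenyl ring carrying halogen. An unsubstituted phenyl, or a phenyl carrying an amine or a carboxylic acid, remains an open case.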